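Trimming isopropyl to ethyl: a step hidden behind a limit

The source may report more compounds than this note shows. Statements on the series, on what has been measured and on what is new or still open speak of the compounds shown alone.

Compound 1 `CC(=O)N1CCN(c2ccc(CN(C(C)(C)C)S(=O)(=O)Cc3ccccc3)cc2)CC1`: <= 1000 nM
Compound 2 `CC(=O)N1CCN(c2ccc(CN(C(C)C)S(=O)(=O)Cc3ccccc3)cc2)CC1`: <= 1000 nM

Both entries come from a physicochemical assay for solubility, in phosphate buffer, measured as kinetic solubility, with a stated time of 24 h, at pH 7.4 (a higher number here means a more soluble compound, a lower number a less soluble compound), and neither is an exact number. Compound 2 stands only at a limit, <= 1000 nM. Compound 1 likewise gives only a limit, <= 1000 nM. The data therefore show (the limit of <= 1000 nM in this assay, at which 2 of the 2 values shown sit).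

Compound 3 `CCN(Cc1ccc(N2CCN(C(C)=O)CC2)cc1)S(=O)(=O)Cc1ccccc1` differs from compound 2 by one small change: hydrogen in place of methyl on a saturated chain carbon bound to a saturated chain carbon and a sulfonamide nitrogen. In words, this is hydrogen in place of methyl on a saturated chain carbon bound to a saturated chain carbon and a sulfonamide nitrogen, or isopropyl to ethyl.

For the measured compounds named here, the only measured step that bears on this, a step that the two limits leave unreadable from compound 1 to compound 2, was a similar swap of hydrogen for methyl, and it offers no size to carry over. No step beyond the scatter is therefore expected, no direction is favoured, and another limit is the likeliest report. The expected step in this assay is a step that the limit leaves unreadable from compound 2 to compound 3. For compound 3 the estimated value is 700 nM, expected to fall between 250 nM and 2500 nM.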

Compound 3, solubility: 31000 nM
Beside the measured number, compound 3's estimate is 44-fold (1.65 log units) below it; measured number above the stated range.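

The sulfonamide nitrogen substituent proves to be a place where a small edit can have a readable effect: in this assay, trimming isopropyl to ethyl gives an at least 31-fold higher number from compound 2 to compound 3 (1.49 log units; beyond the scatter). The change of ethyl in place of tert-butyl on a sulfonamide nitrogen gives an at least 31-fold higher number from compound 1 to compound 3 (1.49 log units; beyond the scatter), so the larger edit shows a step of the same printed size, and neither step can be ranked against the other. The step between the two bulkier compounds cannot be read, and both steps above are minimum sizes, with the true gaps possibly larger, since each starts from the same limit: the limit of <= 1000 nM in this assay, at which 2 of the 3 values shown sit.

As far as these compounds go, what stays open is whether the loss of the branch or the loss of a carbon goes with the step, a question that a straight propyl chain on the same nitrogen would address. It is also unknown whether the trend runs on to a methyl group or a bare hydrogen on that nitrogen, or how a chain ending in an amine or a carboxylic acid would read in this assay.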